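Fluoro for Bromo on a Lanosterol Synthase Series

A few compounds are considered here, and "the series" means these few. Any claim that something is new, unique, unknown or untested is made for them only; others in the source may bear on it.

Compound 1 `O=C(N1CCN(c2ccncc2Cl)CC1)N1CCN(S(=O)(=O)c2ccc(Br)cc2)CC1`: 100%
Compound 2 `O=C(N1CCN(c2ccncc2Cl)CC1)N1CCN(S(=O)(=O)c2ccc(F)cc2)CC1`: 100%
Compound 3 `O=C(N1CCC(c2ccncc2)CC1)N1CCN(S(=O)(=O)c2ccc(Br)cc2)CC1`: 94%

In an assay for inhibition of lanosterol synthase (Rattus norvegicus), using microsomes, tested at 100 nM (a lower number here means less inhibition, a higher number more inhibition at the concentration tested (going by the name of the read-out)), compound 1 gives 100% and compound 2 gives 100%. The change between them, (fluoro in place of bromo on an aromatic carbon), made a step of no change at the digits printed from compound 1 to compound 2 (within the scatter). Compound 3 carries a different core; how the two cores differ is not broken down here. In this assay compound 3 gives 94%, within the scatter of both compound 1 and compound 2.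

Compound 4 `O=C(N1CCC(c2ccncc2)CC1)N1CCN(S(=O)(=O)c2ccc(F)cc2)CC1` has not yet been measured. It differs from compound 3 by fluoro in place of bromo on an aromatic carbon, the same change that turned compound 1 into compound 2. Because that step read no change at the digits printed from compound 1 to compound 2 (within the scatter), the step from compound 3 to compound 4 is expected to be a number 2 percentage points lower from compound 3 to compound 4 (within the scatter). Compound 4 is therefore estimated at 92%, likely between 80% and 100%.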

Compound 4, a percentage reported as inhibition, at one concentration (the size of the read-out at that concentration, not a potency): 97%
For compound 4 the middle estimate is 5 percentage points below the measured one, and the stated range covers the measured number.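

In this assay, fluoro in place of bromo on the core of compound 3 made a step of a number 3 percentage points higher from compound 3 to compound 4 (within the scatter). Set beside the earlier step, the change reads alike on both cores: the same change on two cores in this assay, no change at the digits printed (within the scatter) from compound 1 to compound 2 and a number 3 percentage points higher (within the scatter) from compound 3 to compound 4, 3 percentage points apart, within the scatter of two such steps. This shows that the change carried across these two cores without a difference beyond the scatter, but a percentage at one concentration is not a potency, any difference in potency could stay hidden in it, and two cores make no rule for the whole series.

The compounds shown carry only bromo and fluoro at this place on the aromatic ring. From the compounds shown here alone, whether a nitrile, a methoxy group or an amine there would read the same remains open, as does the behaviour of this change on other cores.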